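Trifluoromethyl for Chlorophenoxy in an Acylguanidine Series

The source may report more compounds than this note shows. Statements on the series, on what has been measured and on what is new or still open speak of the compounds shown alone.

Compound 1, `Cc1cc(F)c(S(C)(=O)=O)cc1C(=O)N=C(N)N`: 44 nM
Compound 2, `Cc1cc(-c2ccc(Cl)cc2)c(S(C)(=O)=O)cc1C(=O)N=C(N)N`: 45 nM
Compound 3, `Cc1cc(Oc2ccccc2Cl)c(S(C)(=O)=O)cc1C(=O)N=C(N)N`: 14 nM

Of the compounds shown here, three have been tested in a functional assay for inhibition of sodium/hydrogen exchanger (Oryctolagus cuniculus); a higher number here means a weaker inhibitor, a lower number a stronger inhibitor. Compound 1 gives 44 nM and compound 2 gives 45 nM; these two numbers lie within the scatter of each other, as a 1.0-fold higher number from compound 1 to compound 2 (0.01 log units; within the scatter) shows. Compound 3 holds the lowest number of the three, with 14 nM; the step of a 3.1-fold lower number from compound 1 to compound 3 (0.50 log units; beyond the scatter) and the step of a 3.2-fold lower number from compound 2 to compound 3 (0.51 log units; beyond the scatter) both lie beyond the scatter, so compound 3 stands apart from the other two.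

Compound 4, `Cc1cc(C(F)(F)F)c(S(C)(=O)=O)cc1C(=O)N=C(N)N`, has not yet been measured. It differs from compound 3 as follows: trifluoromethyl in place of 2-chlorophenoxy on an aromatic carbon. Among the compounds with values here, no measured compound carries a trifluoromethyl group on this aromatic carbon, so the nearest guidance comes from compound 1, whose fluoro group on the same carbon gives 44 nM. The step of a 3.1-fold lower number from compound 1 to compound 3 (0.50 log units; beyond the scatter) suggests that removing the 2-chlorophenoxy group is likely to undo that gain, and compound 2 shows that a 4-chlorophenyl group gives a number like that of compound 1. Compound 4 is therefore expected to move back toward compound 1, a step of a 2.9-fold higher number from compound 3 to compound 4 (0.46 log units; beyond the scatter). The estimate for compound 4 is 40 nM, with a range of 15 nM to 110 nM.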

Compound 4, half-maximal inhibitory concentration: 37 nM
Compound 4: the middle estimate sits 1.1-fold (0.03 log units) above what was measured, and the stated range covers the measured number.
By their numbers in this assay, from the lowest: compound 3; then compounds 4, 1 and 2 (each within the scatter of the next).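

In this assay, trifluoromethyl on this aromatic carbon, ortho to a methylsulfonyl group, cannot be told apart from fluoro (a 1.2-fold lower number from compound 1 to compound 4 (0.08 log units; within the scatter)) or from 4-chlorophenyl (a 1.2-fold lower number from compound 2 to compound 4 (0.09 log units; within the scatter)), so three quite different groups now share one level here. Only 2-chlorophenoxy stands apart, and trifluoromethyl in its place gives a 2.6-fold higher number from compound 3 to compound 4 (0.42 log units; beyond the scatter); the lower number of compound 3 is therefore tied to 2-chlorophenoxy among the four groups shown, and compound 2 shows that an aromatic ring on this carbon does not by itself bring it. Nothing measured here accounts for why compound 3 differs from the other three.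

The compounds shown leave open whether the lower number of compound 3 rests on the oxygen link, on the chlorine, or on where that chlorine sits on the ring. From the compounds shown here alone, an unsubstituted phenoxy, a 4-chlorophenoxy or an anilino group on this carbon would separate these readings, and it also remains open whether an amine or a methoxy here would join the level of compounds 1, 2 and 4.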